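Methoxy to Ethoxy on a Potent Compound

The compounds below may be only part of what the source reports. "The series", "measured", "known", "first", "only" and "open" are said of these compounds alone.

Within the data shown here, in a functional assay on HL-60 cells (Homo sapiens) for inhibition, read by resazurin assay, with a stated time of 72 h (a lower number here means a stronger inhibitor, a higher number a weaker inhibitor), compound 1 `COc1ccc(C2C(O)C(=O)N2c2cc(OC)c(OC)c(OC)c2)cc1` gives 13 nM and holds the lower of the two numbers so far, while compound 2 `C=CC1C(=O)N(c2cc(OC)c(OC)c(OC)c2)C1c1ccc(OC)cc1` gives 33 nM as the higher one. Compound 3 `CCOc1ccc(C2C(O)C(=O)N2c2cc(OC)c(OC)c(OC)c2)cc1` differs from compound 1 by methyl in place of hydrogen on a saturated chain carbon bound to an oxygen on an aromatic ring and so carries 4-ethoxyphenyl in place of 4-methoxyphenyl. Among the measured compounds shown here, the one measured step of a 2.5-fold higher number from compound 1 to compound 2 (0.40 log units; beyond the scatter) puts vinyl in place of hydroxy at a different place, so it offers only a rough scale. A small rise is expected, with the estimated step of a 1.8-fold higher number from compound 1 to compound 3 (0.27 log units; within the scatter) staying within the scatter. Compound 3 is estimated at 24 nM with 8 nM to 70 nM as the likely range.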

Compound 3, half-maximal inhibitory concentration: 11 nM
For compound 3 the middle estimate is 2.2-fold (0.34 log units) above the measured one; the measured number falls inside the stated range.
By their numbers in this assay, from the lowest: compounds 3 and 1 (each within the scatter of the next); then compound 2.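

Replacing 4-methoxyphenyl with 4-ethoxyphenyl gives a 1.2-fold lower number from compound 1 to compound 3 (0.07 log units; within the scatter), so compound 1 and compound 3 cannot be told apart in this assay. Among these compounds, this is the first look at this position, and it shows that a methyl added on the saturated chain carbon bound to the oxygen leaves the number in the same range as that of compound 1. Nothing available here offers an explanation for this result.

The compounds shown leave open how a longer chain, such as propoxy or butoxy, would fare at this place. As far as these compounds go, whether an amine in place of the ethoxy would keep a number like these also remains open.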